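Ethyl in Place of Hydrogen, Carried Across Two Cores

A few compounds are considered here, and "the series" means these few. Any claim that something is new, unique, unknown or untested is made for them only; others in the source may bear on it.

Of the compounds shown here, three have been measured in a functional assay on a cell-free system (Platelet, plasma, Oryctolagus cuniculus) for inhibition, with a stated time of 5 min, at 37 degrees C; a lower number here means a stronger inhibitor, a higher number a weaker inhibitor. Compound 1 `COc1ccc(/C=C/C(=O)O)c(OC(=O)c2nc(C)c(C)nc2C)c1` gives 134000 nM. Compound 2 `CCOC(=O)/C=C/c1ccc(OC)cc1OC(=O)c1nc(C)c(C)nc1C` gives 28200 nM in this assay. Compound 3 `COc1ccc(/C=C/C(=O)O)cc1OC(=O)c1nc(C)c(C)nc1C` gives 41800 nM in this assay. Compound 1 and compound 3 are built from the same atoms joined differently; the difference between the two cores is not broken down here. Compound 3 and compound 2 lie within the scatter of each other, whereas compound 3 stands beyond the scatter from compound 1.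

For the measured compounds named here, the one measured change in a single place is ethyl in place of hydrogen on an oxygen next to a carbonyl group, and it made a 4.8-fold lower number from compound 1 to compound 2 (0.68 log units; beyond the scatter). Compound 4 `CCOC(=O)/C=C/c1ccc(OC)c(OC(=O)c2nc(C)c(C)nc2C)c1` has not yet been measured; it carries the same change relative to compound 3, namely (ethyl in place of hydrogen on an oxygen next to a carbonyl group), at the same place. The same change on the core of compound 3 is expected to make a 3.8-fold lower number from compound 3 to compound 4 (0.58 log units; beyond the scatter), because the measured step of a 4.8-fold lower number from compound 1 to compound 2 (0.68 log units; beyond the scatter) was modest, with added uncertainty since the two cores differ. Compound 4 is therefore estimated at 11000 nM, expected to fall between 4000 nM and 30000 nM.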

Compound 4, half-maximal inhibitory concentration: 143000 nM
Beside the measured number, compound 4's estimate is 13-fold (1.11 log units) below it; the measured number lies above the stated range.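

In this assay, ethyl in place of hydrogen on an oxygen next to a carbonyl group gave a 3.4-fold higher number from compound 3 to compound 4 (0.53 log units; beyond the scatter). The same change moved the number in opposite directions on the two cores, so in this series its effect depends on the core that carries it: the same change on two cores in this assay, a 4.8-fold lower number (0.68 log units; beyond the scatter) from compound 1 to compound 2 and a 3.4-fold higher number (0.53 log units; beyond the scatter) from compound 3 to compound 4, 16-fold (1.21 log units) apart, beyond the scatter of two such steps

This shows that a step measured on one of these cores cannot simply be transferred to the other, even when the two cores are built from the same atoms; it does not show which feature of the cores is responsible, and two pairs say nothing about how the change would behave on any further core.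

On these data alone, whether a methyl group or a longer chain on that oxygen would split the same way between the two cores remains open. Also open, as far as these compounds go, is what an amide would do in place of the carboxylic acid on each core.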